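This account rests on a few compounds, and the source may have more. Where it says the series, first, only, none or still open, it means among the compounds named here.

Compound 1 `O=C(O)Cn1c(=O)c(/C=C/c2ccc(O)c(O)c2)nc2cc(Cl)cnc21` gives, in a functional assay, read by spectrophotometry, with a stated time of 30 min, tested at 10 uM (on this read-out higher numbers stand for a stronger effect at the one concentration tested and lower numbers for a weaker effect), a value of 74.7%, the higher of the two numbers in hand. Compound 3 `COc1cc(/C=C/c2nc3cc(Cl)cnc3n(CC(=O)O)c2=O)ccc1O`, which carries a methyl in place of hydrogen on an oxygen on an aromatic ring, gives 62.3% in this assay, and the step from compound 1 to compound 3 amounts to a number 12.4 percentage points lower from compound 1 to compound 3 (beyond the scatter). For compound 2 `COc1cc(O)cc(-c2nc3cccnc3n(CC(=O)O)c2=O)c1` this assay reports "not determined" (no result reported), so nothing can be said of it. Compound 4 `O=C(O)Cn1c(=O)c(/C=C/c2ccc(O)c(O)c2)nc2cc(Br)cnc21` is the next entry, and it differs from compound 1 only by bromo in place of chloro on an aromatic carbon. Going by the values given here, none of the measured steps bears on this change: the single step in hand concerns the methyl on an oxygen, not the halogen on the fused ring, and no other pair differs only by a bromo in place of a chloro. With nothing to point either way, the exchange of one halogen for another at the same place is expected to move the activity little, so the step from compound 1 to compound 4 is expected to be a number 2.7 percentage points lower from compound 1 to compound 4 (within the scatter), within the scatter. Compound 4 is therefore estimated to give 72% in this assay, with a range from 55% to 86%.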

Compound 4, a percentage reported as activity, at one concentration (the size of the read-out at that concentration, not a potency): 70.8%
For compound 4 the middle estimate is 1.2 percentage points above the measured one; measured number inside the range.
By their numbers in this assay, from the lowest: compounds 3, 4 and 1 (each within the scatter of the next, the first and the last beyond it).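

At this position, on an aromatic carbon of the six-membered aromatic ring with 1 nitrogen and two atoms from the ring nitrogen, bromo in place of chloro gives a number 3.9 percentage points lower from compound 1 to compound 4 (within the scatter) in this assay, so this exchange leaves the read-out within its usual scatter. Going by these compounds alone, the only earlier step, a number 12.4 percentage points lower from compound 1 to compound 3 (beyond the scatter), concerned a methyl on an oxygen and lay beyond the scatter, so this is the first sign that the halogen place can take a second halogen with no change that can be told from scatter. Nothing in hand explains why the exchange has so small an effect.

The compounds shown leave open how the same carbon would respond to a group other than a halogen, such as an amine or a nitrile. They also leave open whether bromo would give a similar result alongside the methyl on the oxygen found in compound 3.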